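Replacing the chloroindazole in a diaryl urea series

The source may hold more compounds than are shown below. What is called first, only, known or untested is meant among the compounds shown, and "the series" means these compounds.

Among the measured compounds shown here, compound 2 `O=C(Nc1ccc(-n2ncc3c(Cl)cccc32)cc1)Nc1ccc(Cl)c(C(F)(F)F)c1` is one of only two compounds measured so far in a functional assay on HT-29 cells (Homo sapiens) for cytotoxicity, read by MTT assay, with a stated time of 72 h (on this read-out higher numbers stand for weaker inhibition and lower numbers for stronger inhibition), where compound 2 gives 4600 nM, and compound 1 `O=C(Nc1ccc(-n2ncc3c(C(F)(F)F)cccc32)cc1)Nc1ccc(Cl)c(C(F)(F)F)c1` gives 2900 nM; the step of a 1.6-fold higher number from compound 1 to compound 2 (0.20 log units; within the scatter) keeps the two within the scatter of each other. Compound 3 `O=C(Nc1ccc(-n2ncc3cnccc32)cc1)Nc1ccc(Cl)c(C(F)(F)F)c1` carries a group of 9 heavy atoms (6 carbon, 3 nitrogen; one five-membered aromatic ring with 2 hetero atoms, one six-membered aromatic ring with 1 hetero atom) in place of a group of 10 heavy atoms (7 carbon, 2 nitrogen, 1 chlorine; one five-membered aromatic ring with 2 hetero atoms, one six-membered aromatic ring of carbon only), on an aromatic carbon. No measured step bears on this change, and the one step shown, a single ring substituent exchange, stayed within the scatter. No step beyond the scatter is therefore expected, the estimated step being a 1.3-fold higher number from compound 2 to compound 3 (0.12 log units; within the scatter). Compound 3 is estimated at 6000 nM, within a range of 2000 nM to 20000 nM.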

Compound 3, half-maximal inhibitory concentration: 10500 nM
Estimate against measurement, compound 3: 1.8-fold (0.24 log units) below; measured number inside the range.
By their numbers in this assay, from the lowest: compounds 1 and 2 (each within the scatter of the next); then compound 3.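

In this assay, among the compounds shown here, the change at this position gives the only step so far beyond the scatter, though a modest one: a 2.3-fold higher number from compound 2 to compound 3 (0.36 log units; beyond the scatter). The exchange of chloro and trifluoromethyl stayed within the scatter, whereas replacing 4-chloro-1H-indazol-1-yl, with a hetero atom entering the six-membered ring, moves the number towards weaker inhibition. No available evidence accounts for this step. The compounds shown leave open how far the ring nitrogen alone matters, as the chlorine leaves in the same change. They also leave open whether an amine or a methoxy group on the new ring would alter the number.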